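Branching the side chain: from propyl to isopropyl

The compounds below may be only part of what the source reports. "The series", "measured", "known", "first", "only" and "open" are said of these compounds alone.

Three compounds share one core. Compound 1 `Cc1ccccc1C(=O)N[C@@H](C(=O)N1CCC(c2ccc(Cl)cc2)CC1)C(C)C` gives 32 nM in an assay on THP-1 cells for displacement of a labelled ligand from C-C chemokine receptor type 1 (Homo sapiens) (a lower number here means a stronger inhibitor, a higher number a weaker inhibitor), compound 3 `CC[C@@H](C)[C@@H](NC(=O)CCc1ccccc1)C(=O)N1CCC(c2ccc(Cl)cc2)CC1` gives 66 nM, and compound 2 `CCCC(NC(=O)c1ccccc1C)C(=O)N1CCC(c2ccc(Cl)cc2)CC1` gives 152 nM, the highest of the three numbers, beyond the scatter from both others. Compound 4 `Cc1ccccc1C(=O)NC(C(=O)N1CCC(c2ccc(Cl)cc2)CC1)C(C)C` has not yet been measured. It differs from compound 2 by isopropyl in place of propyl on a saturated chain carbon bound to an amide-type nitrogen and a carbonyl carbon, so the two hold the same atoms joined differently. Among the measured compounds shown here, no directly comparable step is at hand, but compound 1, which also carries an isopropyl at that carbon, gives 32 nM. The account therefore expects the number for compound 4 to fall, by the step of a 2.5-fold lower number from compound 2 to compound 4 (0.40 log units; beyond the scatter) in this assay. Compound 4 is estimated at 60 nM, within 30 nM to 130 nM.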

Compound 4, half-maximal inhibitory concentration: 36 nM
Beside the measured number, compound 4's estimate is 1.7-fold (0.22 log units) above it, within the range that was stated.
By their numbers in this assay, from the lowest: compounds 1, 4 and 3 (each within the scatter of the next, the first and the last beyond it); then compound 2.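

Isopropyl in place of propyl on a saturated chain carbon bound to an amide-type nitrogen and a carbonyl carbon can now be read directly in this assay, with a 4.2-fold lower number from compound 2 to compound 4 (0.63 log units; beyond the scatter), so the branching of this side chain matters to the number. Drawing the configuration at that carbon leaves the number within the scatter, with a 1.1-fold higher number from compound 1 to compound 4 (0.05 log units; within the scatter). The reading of that pair rests on a single difference: the fact that one of compounds 1 and 4 is drawn with a defined configuration and the other without, at the place where they differ.

Left open is how the opposite configuration at this carbon would read, and how a longer chain or an amine there would compare with isopropyl.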